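Methoxycarbonyl for methyl on the core of compound 3

A few compounds are considered here, and "the series" means these few. Any claim that something is new, unique, unknown or untested is made for them only; others in the source may bear on it.

Three compounds have numbers in an assay on RPMI-8226 cells for antagonist activity at P2X purinoceptor 7 (Homo sapiens), read by calcium flux; on this read-out higher numbers stand for weaker inhibition and lower numbers for stronger inhibition. Compound 1 `O=c1[nH]c2ccccc2n1CCCCN1CCN(C(c2ccccc2)c2ccccc2)CC1` gives 180 nM. Compound 2 `Cc1cc2ncn(CCCCN3CCN(C(c4ccccc4)c4ccccc4)CC3)c2cc1C` gives 770 nM, and compound 3 `Cc1cccc2ccn(CCCCN3CCN(C(c4ccccc4)c4ccccc4)CC3)c12` gives 2300 nM. Compound 3 stands highest of the three: the step of a 13-fold higher number from compound 1 to compound 3 (1.11 log units; beyond the scatter) and the step of a 3.0-fold higher number from compound 2 to compound 3 (0.48 log units; beyond the scatter) both lie beyond the scatter, as does a 4.3-fold higher number from compound 1 to compound 2 (0.63 log units; beyond the scatter). Compound 4 `COC(=O)c1cccc2ccn(CCCCN3CCN(C(c4ccccc4)c4ccccc4)CC3)c12` differs from compound 3 in one place: methoxycarbonyl in place of methyl on an aromatic carbon, on an aromatic carbon of the six-membered ring, ortho to a fused ring and meta to a fused ring. For the measured compounds named here, none of the measured steps bears on this change; each of them exchanges the whole bicyclic group four bonds along the chain from the amine nitrogen in a ring, and none alters a single substituent on a retained core. Going by the values given here, with no comparable step to lean on, the expectation for compound 4 in this assay is no step beyond the scatter, held with a wide range: the estimate for compound 4 is 2300 nM, ranging from 800 nM to 6500 nM. Expected in this way, the step is no change at the digits printed from compound 3 to compound 4 (within the scatter).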

Compound 4, half-maximal inhibitory concentration: > 10000 nM
Compound 4 ended at the assay's limit (the forecaster's own chance of this, stated with the estimate: 5%); middle value at least 4.3-fold (0.63 log units) from the limit.
By their numbers in this assay, from the lowest: compound 1; then compound 2; then compound 3. At a limit, above all of these: compound 4.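

In this assay, for the compounds shown here, this is the first exchange of a single substituent on a retained core, and methoxycarbonyl in place of methyl on this aromatic carbon, ortho to a fused ring and meta to a fused ring, weakens inhibition: an at least 4.3-fold higher number from compound 3 to compound 4 (0.63 log units; beyond the scatter). The value of compound 4 is a limit of the assay and not a number: the limit of > 10000 nM in this assay, at which 1 of the 4 values shown sits. The step therefore fixes a direction and a minimum size, so this position responds to a single substituent change on the core of compound 3.

The compounds shown leave open whether the weakening follows the larger group or its hydrogen-bond acceptors; an ethyl, a hydroxymethyl or a carboxylic acid at this position would help separate these. Also open, from the compounds shown here alone, is how an unsubstituted carbon at this position compares with methyl.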